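This account rests on a few compounds, and the source may have more. Where it says the series, first, only, none or still open, it means among the compounds named here.

Two compounds measured in a functional assay on NCI-H1975 cells (Homo sapiens) for inhibition, read by MTT assay, with a stated time of 72 h (on this read-out higher numbers stand for weaker inhibition and lower numbers for stronger inhibition), set the frame. Compound 1 `O=C(CSc1nc(Nc2ccccc2)c2ccccc2n1)Nc1ccc(Cl)c(Cl)c1` gives 10400 nM in this assay. Compound 2 `C=CC(=O)Nc1cccc(NC(=O)CSc2nc(Nc3ccccc3Br)c3ccccc3n2)c1` gives 19300 nM in this assay, the higher of the two numbers, though its gap to compound 1 lies within the scatter of repeated measurements, so the two cannot be told apart.

The unmeasured compound 3 `C=CC(=O)Nc1cccc(NC(=O)CSc2nc(Nc3ccc(F)cc3)c3ccccc3n2)c1` differs from compound 2 in one place: 4-fluorophenyl in place of 2-bromophenyl on a nitrogen on an aromatic ring. For the measured compounds named here, no measured pair in this set shows that exchange, so the two values give no direct guide to its size. With nothing to point one way or the other, a small step in this assay is expected, not beyond the scatter in either direction.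

On that basis compound 3 is estimated at 16000 nM in this assay, with a range from 5000 nM to 50000 nM, which corresponds to the expected step of a 1.2-fold lower number from compound 2 to compound 3 (0.08 log units; within the scatter). Going by the values given here, the uncertainty is wide, since the exchange at the nitrogen on the aromatic ring has no measured counterpart here.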

Compound 3, half-maximal inhibitory concentration: 4430 nM
Compound 3: middle estimate off by 3.6-fold (0.56 log units), on the high side; measured number outside the range, below it.
By their numbers in this assay, from the lowest: compound 3; then compounds 1 and 2 (each within the scatter of the next).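

Compound 3 gives the first readable result at this position: in this assay, the nitrogen on an aromatic ring carries a group whose exchange registers, with 4-fluorophenyl in place of 2-bromophenyl giving a 4.4-fold lower number from compound 2 to compound 3 (0.64 log units; beyond the scatter) while the rest of the molecule stays the same. The step is modest but beyond the scatter, and it arises between two groups that have the same heavy-atom count and the same hydrogen-bond donor and acceptor counts, so those counts do not separate them; what differs is the halogen and where it sits on the phenyl ring. Nothing measured here accounts for the step.

Because the halogen and its place change together in this single exchange, the compounds shown leave open which of the two carries the step, and a 4-bromophenyl or a 2-fluorophenyl group on this nitrogen would separate them. Also open, as far as these compounds go, is how a group without a halogen, such as 4-methoxyphenyl, would stand at this position.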